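The source may report more compounds than this note shows. Statements on the series, on what has been measured and on what is new or still open speak of the compounds shown alone.

Compounds measured so far in an ADME assay on Huh-7 cells (Homo sapiens) for cytotoxicity, with a stated time of 3 days; on this read-out lower numbers stand for higher toxicity in this test and higher numbers for lower toxicity in this test:
Compound 1 `COc1ccccc1NC(=O)c1c(NO)cc(-c2ccccc2)oc1=O` gives > 20000 nM, which is a limit of the assay and not a number.
Compound 2 `CCOc1ccccc1NC(=O)c1c(NO)cc(-c2ccccc2)oc1=O` gives > 20000 nM, also a limit.
Compound 3 `O=C(Nc1ccc(F)cc1)c1c(NO)cc(-c2cccs2)oc1=O` gives > 20000 nM, again a limit.

Compound 3 therefore stands at the same limit as the other two compounds, and no number separates it from them. Among the compounds with values here, the single change measured so far, a step that the two limits leave unreadable from compound 1 to compound 2, cannot be read in size, since every value sits at the limit of > 20000 nM in this assay, at which 3 of the 3 values shown sit. Compound 4 `Cc1ccc(NC(=O)c2c(NO)cc(-c3cccs3)oc2=O)cc1` differs from compound 3 by methyl in place of fluoro on an aromatic carbon. Within the data shown here, no measured step bears on this change, so no shift beyond the scatter is expected in this assay. The expected change is a step that the limit leaves unreadable from compound 3 to compound 4. Compound 4 is thus estimated at 30000 nM, with a range from 12000 nM to 100000 nM, most likely again reported only as a limit.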

Compound 4, half-maximal cytotoxic concentration: > 20000 nM
Compound 4 gave a limit, no number; the forecaster's own chance of this, stated with the estimate: 85%; the middle value lies beyond the limit too.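

The step from fluoro to methyl between compound 3 and compound 4 cannot be read in size, since both compounds give only a limit and not a number: the limit of > 20000 nM in this assay, at which 4 of the 4 values shown sit. The compounds shown leave open whether any of these changes shifts the result in this assay at all.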